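Halogen swap ortho to the phenol in a nonanamide series

The source may report more compounds than this note shows. Statements on the series, on what has been measured and on what is new or still open speak of the compounds shown alone.

Measured so far:
compound 1 `CCCCCCCCC(=O)NCc1cc(I)c(O)c(OC)c1` — 126 nM
compound 2 `CCCCCCCCC(=O)NCc1cc(OC)c(O)cc1Cl` — 50.3 nM

Of the compounds shown here, two have been measured in an assay on HEK293 cells for inhibition of transient receptor potential cation channel subfamily V member 1 (Homo sapiens); on this read-out lower numbers stand for stronger inhibition and higher numbers for weaker inhibition. Compound 1 `CCCCCCCCC(=O)NCc1cc(I)c(O)c(OC)c1` gives 126 nM, the higher of the two numbers. Compound 2 `CCCCCCCCC(=O)NCc1cc(OC)c(O)cc1Cl` gives 50.3 nM, the lower one; the gap between the two lies beyond the usual scatter, but the two structures differ in more than one place, so no single-change step can be read from them.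

Compound 3 `CCCCCCCCC(=O)NCc1cc(Cl)c(O)c(OC)c1` is the next candidate. It differs from compound 1 in one place: chloro in place of iodo on an aromatic carbon. Within the data shown here, no measured pair shows this change on its own, so the direction has to be guessed. With iodo replaced by the smaller chloro in the same position, the expectation is a modest weakening, a step of a 2.0-fold higher number from compound 1 to compound 3 (0.30 log units; within the scatter), which is expected to sit near the edge of the scatter rather than clearly outside it.

Compound 3 is therefore expected to give 250 nM, with a range of 100 nM to 630 nM in this assay .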

Compound 3, half-maximal inhibitory concentration: 631 nM
Estimate against measurement, compound 3: 2.5-fold (0.40 log units) below, outside the stated range (above it).
By their numbers in this assay, from the lowest: compound 2; then compound 1; then compound 3.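

In this assay, among these compounds, chloro in place of iodo on the aromatic carbon ortho to a hydroxy group gives a 5.0-fold higher number from compound 1 to compound 3 (0.70 log units; beyond the scatter), the first single-change step and one that lies beyond the usual scatter. Among the compounds shown here, this shows that the choice of halogen at this position is not neutral: with everything else in the core of compound 1 held fixed, the iodo compound has the lower number and therefore the stronger inhibition, while compound 2 differs from both in more than one place, so no step to it can be read. For the compounds shown here, nothing measured so far bears on the reason for this difference between iodo and chloro.

As far as these compounds go, whether bromo or fluoro at the same carbon would fall between or outside these two values remains open, as does the result with a plain hydrogen or a methyl group there, which would show whether the halogen itself adds to or takes from the read-out. From the compounds shown here alone, it is also open whether the same iodo-to-chloro step holds with a chain other than the one in the nonanamide, such as a shorter acyl chain or a longer one.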